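A few compounds are considered here, and "the series" means these few. Any claim that something is new, unique, unknown or untested is made for them only; others in the source may bear on it.

Compound 3 `Fc1cccc(-c2nc(Nc3cccc(Br)c3)c3cc(F)ccc3n2)c1` is one of the weaker members of this small set: in a functional assay on U2OS cells (Homo sapiens) for cytotoxicity, read by MTT assay, with a stated time of 48 h (on this read-out lower numbers stand for stronger inhibition and higher numbers for weaker inhibition), compound 3 reaches only the limit of the assay, > 50000 nM. Compound 2 `Fc1cccc(-c2nc(Nc3ccccc3Cl)c3cc(F)ccc3n2)c1` likewise stops at a limit in this assay, > 50000 nM. Compound 1 `COc1ccc(Nc2nc(-c3cccc(F)c3)nc3ccc(F)cc23)cc1` gives a number in this assay, 32300 nM, so that an at least 1.5-fold higher number from compound 1 to compound 3 (0.18 log units; that floor lies within the scatter) and an at least 1.5-fold higher number from compound 1 to compound 2 (0.18 log units; that floor lies within the scatter) are read only as floors, while a step that the two limits leave unreadable from compound 2 to compound 3 cannot be sized at all. Two of the three values sit at the same limit (the limit of > 50000 nM in this assay, at which 2 of the 3 values shown sit). Compound 4 `Oc1cccc(Nc2nc(-c3cccc(F)c3)nc3ccc(F)cc23)c1` carries hydroxy in place of bromo on an aromatic carbon. Within the data shown here, no measured step swaps a halogen for a hydroxy group here, so the expectation is weak: compound 4 is expected to land near 45000 nM (range 15000 nM to 200000 nM), an expected step of an at least 1.1-fold lower number from compound 3 to compound 4 (0.04 log units; that floor lies within the scatter), with a fair chance of another limit.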

Compound 4, half-maximal inhibitory concentration: 33300 nM
Estimate against measurement, compound 4: 1.4-fold (0.13 log units) above; measured number inside the range.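

With hydroxy in place of bromo on the aromatic carbon, this assay gives a number where only a limit stood, and the change reads as an at least 1.5-fold lower number from compound 3 to compound 4 (0.17 log units; that floor lies within the scatter), alongside an at least 1.5-fold lower number from compound 2 to compound 4 (0.17 log units; that floor lies within the scatter). Both are only floors, as each starts from a limit: the limit of > 50000 nM in this assay, at which 2 of the 4 values shown sit.

Against the one other number the step is a 1.0-fold higher number from compound 1 to compound 4 (0.01 log units; within the scatter), so 3-hydroxyphenyl and 4-methoxyphenyl on the nitrogen do not separate here. Going by these compounds, whether an amine or a carboxylic acid in this place would move the number beyond the scatter stays open. So does whether any group on this ring gives a clearly stronger inhibition than compound 1 and compound 4 do.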